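A few compounds are considered here, and "the series" means these few. Any claim that something is new, unique, unknown or untested is made for them only; others in the source may bear on it.

Measured so far in a functional assay on CCRF-CEM cells (Homo sapiens) for antiproliferative activity, with a stated time of 72 h; a higher number here means a weaker inhibitor, a lower number a stronger inhibitor:

- compound 1, `OC[C@H]1O[C@@H](n2cnc3c(NCc4ccc(Br)cc4)ncnc32)[C@H](O)[C@@H]1O`: 20600 nM
- compound 2, `OC[C@H]1O[C@@H](n2cnc3c(NCc4ccc(Cl)c(Cl)c4)ncnc32)[C@H](O)[C@@H]1O`: 3800 nM
- compound 3, `OC[C@H]1O[C@@H](n2cnc3c(NCc4cc(F)cc(F)c4)ncnc32)C(O)C1O`: 24500 nM

Compound 2 gives the lowest of the three numbers in this assay. Its distance to compound 1 is the step of a 5.4-fold lower number from compound 1 to compound 2 (0.73 log units; beyond the scatter), which lies beyond the scatter; against compound 3 the two values also stand apart by more than the scatter, so compound 2 is the strongest inhibitor measured here.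

The next compound in the series is compound 4, `Cc1ccc(O)c(CNc2ncnc3c2ncn3[C@@H]2O[C@H](CO)[C@@H](O)[C@H]2O)c1`. It differs from compound 2 in one place: 2-hydroxy-5-methylphenyl in place of 3,4-dichlorophenyl on a saturated chain carbon bound to a nitrogen on an aromatic ring. Going by the values given here, the only measured step at this place is a 5.4-fold lower number from compound 1 to compound 2 (0.73 log units; beyond the scatter), which shows that exchanging one halogenated phenyl for another can move the number by a modest amount. Among the compounds with values here, no measured compound carries a group with a hydrogen-bond donor or acceptor at this place, so that step gives the size a change here can reach, but not the direction for 2-hydroxy-5-methylphenyl.

With only compound 2 as a halogen-free-neighbour-less anchor, the expected step is a modest rise, a 2.6-fold higher number from compound 2 to compound 4 (0.42 log units; beyond the scatter), toward the region of compound 1 and compound 3. The estimated value for compound 4 in this assay is 10000 nM, with the range 3000 nM to 40000 nM.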

Compound 4, half-maximal inhibitory concentration: 1900 nM
For compound 4 the middle estimate is 5.3-fold (0.72 log units) above the measured one, and the stated range ends above it.
By their numbers in this assay, from the lowest: compounds 4 and 2 (each within the scatter of the next); then compounds 1 and 3 (each within the scatter of the next).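

In this assay, 2-hydroxy-5-methylphenyl, with a hydrogen-bond donor and acceptor, and 3,4-dichlorophenyl, with neither, give numbers that cannot be told apart, at a 2.0-fold lower number from compound 2 to compound 4 (0.30 log units; within the scatter), so a low number at this place on a saturated chain carbon bound to a nitrogen on an aromatic ring does not depend on chlorine atoms or on a group free of hydrogen-bond donors. Going by these compounds alone, the same entering group, set against 4-bromophenyl, gives an 11-fold lower number from compound 1 to compound 4 (1.04 log units; beyond the scatter), the largest step so far at this place and wider than a 5.4-fold lower number from compound 1 to compound 2 (0.73 log units; beyond the scatter), which shows that compound 1 rather than compound 2 is the outlying member of these three, and that halogen alone does not set the number, as compound 1 carries bromine and compound 2 carries chlorine. No measurement here speaks to the reason for these steps.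

From the compounds shown here alone, the hydroxy and methyl groups enter together, so the share of each in the result stays open. Also open, going by these compounds, is how the series reads in this assay with an amine or a carboxylic acid on the phenyl ring in place of the hydroxy group.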